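Methyl for fluoro on the aryl arm: cytotoxicity notes

The source may report more compounds than this note shows. Statements on the series, on what has been measured and on what is new or still open speak of the compounds shown alone.

Compound 1 `N#Cc1c(-c2ccc(Cl)cc2)c(C#N)c(=O)n(/N=C/c2cn(-c3ccccc3)nc2-c2ccccc2)c1N` and compound 2 `N#Cc1c(-c2ccc(F)cc2)c(C#N)c(=O)n(/N=C/c2cn(-c3ccccc3)nc2-c2ccccc2)c1N` share one core and differ only in the aryl substituent. In an ADME assay on HeLa cells (Homo sapiens) for cytotoxicity, read by MTT assay (on this read-out lower numbers stand for stronger inhibition and higher numbers for weaker inhibition), compound 1 gives only a limit, > 200 ug/mL. In this assay compound 2 likewise gives only a limit, > 200 ug/mL. The step that the two limits leave unreadable from compound 1 to compound 2, since both values sit at the limit of > 200 ug/mL in this assay, at which 2 of the 2 values shown sit. Compound 3 `Cc1ccc(-c2c(C#N)c(N)n(/N=C/c3cn(-c4ccccc4)nc3-c3ccccc3)c(=O)c2C#N)cc1` is the next member of the series. Its difference from compound 2 is methyl in place of fluoro on an aromatic carbon. For the measured compounds named here, the only measured step that bears on this change is the one from compound 1 to compound 2, and that step cannot be sized from the two limits. The expectation for compound 3 therefore rests on the two limits alone, and the estimated step that the limit leaves unreadable from compound 2 to compound 3 is no step beyond the scatter. Compound 3 is expected to give 300 ug/mL in this assay, within an estimated range from 100 ug/mL to 1000 ug/mL.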

Compound 3, half-maximal inhibitory concentration: > 200 ug/mL
Compound 3 ended at the assay's limit; the forecaster's own chance of this, stated with the estimate: 80%; the middle value lies beyond the limit too.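

No step between compound 1, compound 2 and compound 3 can be read in this assay, since all three values are limits of the assay: the limit of > 200 ug/mL in this assay, at which 3 of the 3 values shown sit.

The compounds shown leave open whether chloro, fluoro and methyl on the aryl arm differ at all in this assay.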